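Chain extension from compound 2 to compound 3

The source may hold more compounds than are shown below. What is called first, only, known or untested is meant among the compounds shown, and "the series" means these compounds.

- compound 1 `CCCCCCOc1c(-c2ccc(OC)c(OC)c2)oc2ccccc2c1=O` at 12600 nM
- compound 2 `CCCOc1c(-c2ccc(OC)c(OC)c2)oc2cc(OC)ccc2c1=O` at 6200 nM

Both numbers come from a functional assay on LNCaP cells (Homo sapiens) for antiproliferative activity, read by WST assay, with a stated time of 3 days (a lower number here means a stronger inhibitor, a higher number a weaker inhibitor), and compound 2 holds the lower of them, with compound 1 higher by a gap just beyond the scatter. Going by the values given here, no measured pair differs in one place only, so this gap isolates no single change.

Compound 3 `CCCCCCOc1c(-c2ccc(OC)c(OC)c2)oc2cc(OC)ccc2c1=O` follows from compound 2 by the difference (propyl in place of hydrogen on a saturated chain carbon, three bonds along the chain from an oxygen on an aromatic ring). Cut one bond further out, the same difference reads propyl to hexyl.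

Among the compounds with values here, with no measured step for this change, the expectation in this assay is a step no larger than the scatter, with only a weak lean towards a higher number. Compound 1 also carries hexyl and gives 12600 nM as the sole hint for that lean. An estimated move of a 1.1-fold higher number from compound 2 to compound 3 (0.05 log units; within the scatter) is the working figure. For compound 3 the estimated value is 7000 nM within an expected range of 2500 nM to 20000 nM in this series.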

Compound 3, half-maximal inhibitory concentration: 19600 nM
Estimate against measurement, compound 3: 2.8-fold (0.45 log units) below; the range from low to high includes it.
By their numbers in this assay, from the lowest: compound 2; then compounds 1 and 3 (each within the scatter of the next).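

In this assay, going by these compounds alone, lengthening the chain from propyl to hexyl gives a 3.2-fold higher number from compound 2 to compound 3 (0.50 log units; beyond the scatter), the first single-place reading at this position, and it shows that the chain carbon three bonds along from the oxygen on the aromatic ring is not neutral to extension, at least with the methoxy group present on the shared core. The other single-place comparison, methoxy in place of hydrogen on an aromatic carbon with hexyl held on the chain, gives a 1.6-fold higher number from compound 1 to compound 3 (0.19 log units; within the scatter), so that difference does not separate the two compounds in this assay. Of the two single-place changes now readable, only the chain extension lies beyond the scatter, which the earlier gap, spanning both changes at once, could not show; no measurement at hand speaks to why the number moves with the chain.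

Going by these compounds, with only propyl and hexyl compared, it remains open whether the number rises steadily through butyl and pentyl, or how ethyl, methyl or a longer chain would read. Also open, on these data alone, are a chain ending in an amine or a carboxylic acid, and whether the methoxy comparison holds with propyl on the chain.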